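Benzoxazole sulfonamides: limits only, methoxy variant

The source may hold more compounds than are shown below. What is called first, only, known or untested is meant among the compounds shown, and "the series" means these compounds.

Compound 1 `O=S(=O)(Nc1ccc2oc(-c3ccccc3)nc2c1)c1ccc(Cl)cc1` is the reference. In an assay on isolated protein for inhibition of malate dehydrogenase, mitochondrial (Sus scrofa), with stated times of 45 min and 30 min (on this read-out lower numbers stand for stronger inhibition and higher numbers for weaker inhibition), compound 1 gives only a limit, > 63000 nM, not a number. Compound 2 `O=S(=O)(Nc1ccc2oc(-c3ccccc3)nc2c1)c1ccc(Cl)c(C(F)(F)F)c1` carries a trifluoromethyl in place of hydrogen on an aromatic carbon. In this assay compound 2 likewise gives only a limit, > 63000 nM. The step that the two limits leave unreadable from compound 1 to compound 2 is therefore unreadable; both values sit at the limit of > 63000 nM in this assay, at which 2 of the 2 values shown sit.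

Compound 3 `COc1ccc(Cl)cc1S(=O)(=O)Nc1ccc2oc(-c3ccccc3)nc2c1` introduces (5-chloro-2-methoxyphenyl in place of 4-chlorophenyl on a sulfonyl sulfur). Within the data shown here, no measured step touches this position, and the one step cannot be sized, so there is no basis for expecting a change beyond the scatter in either direction. With both measured compounds at the limit, compound 3 is expected to remain near that limit as well; the estimated step that the limit leaves unreadable from compound 1 to compound 3 is essentially flat. Compound 3 is thus estimated at 70000 nM in this assay, within 15000 nM to 300000 nM.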

Compound 3, half-maximal inhibitory concentration: > 63000 nM
Compound 3 gave a limit, no number; the forecaster's own chance of this, stated with the estimate: 75%; the middle value lies beyond the limit too.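

Compound 3, like compound 1 and compound 2, gives only a limit in this assay, so no step among these compounds can be read: the limit of > 63000 nM in this assay, at which 3 of the 3 values shown sit.

The compounds shown leave open whether either change alters the read-out at all, as none of them yields a number to compare.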